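The compounds below may be only part of what the source reports. "The series", "measured", "known", "first", "only" and "open" are said of these compounds alone.

Compound 1 `Cc1ccc2ccc(=O)n(CCN(C)C)c2n1` stands at the higher of the two numbers recorded in an assay on isolated protein (strain Charles River) for antagonist activity at histamine H2 receptor (Rattus norvegicus) (a higher number here means that more compound is needed for the effect, a lower number that less compound is needed), where compound 1 gives 2.18 ug/mL. Its nearest neighbour, compound 2 `CC(C)Cc1ccc2ccc(=O)n(CCN(C)C)c2n1`, gives 0.16 ug/mL in this assay. Compound 3 `Cc1cc(C)c2ccc(=O)n(CCN(C)C)c2n1` differs from compound 1 by a (methyl in place of hydrogen on an aromatic carbon). Going by the values given here, the only measured step, a 14-fold lower number from compound 1 to compound 2 (1.13 log units; beyond the scatter), adds carbon at a different place, on the saturated chain, and so bears only loosely on this change. A smaller step is therefore expected for compound 3, namely a 1.8-fold lower number from compound 1 to compound 3 (0.26 log units; within the scatter). Compound 3 is accordingly estimated at 1.2 ug/mL, between 0.4 ug/mL and 3.5 ug/mL.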

Compound 3, half-maximal effective concentration: 3.93 ug/mL
Beside the measured number, compound 3's estimate is 3.3-fold (0.52 log units) below it; the measured number lies above the stated range.
By their numbers in this assay, from the lowest: compound 2; then compounds 1 and 3 (each within the scatter of the next).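

Methyl in place of hydrogen on an aromatic carbon, opposite the ring nitrogen, gives a 1.8-fold higher number from compound 1 to compound 3 (0.26 log units; within the scatter) in this assay, so this position accepts a methyl with no change that can be told from scatter. So far, only the isopropyl change on the saturated chain moves the number beyond the scatter. Nothing available explains this result.

As far as these compounds go, whether a longer chain, a methoxy group or an amine at this position would move the number remains open, as does whether the methyl would behave the same way on the core of compound 2.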